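Extending the amine of compound 1 with a bulky side chain

This account rests on a few compounds, and the source may have more. Where it says the series, first, only, none or still open, it means among the compounds named here.

Measured compounds:
- compound 1, `COc1cc(OC)c(/C=C/S(=O)(=O)Cc2ccc(OC)c(N)c2)c(OC)c1`: 2.5 nM
- compound 2, `COc1cc(OC)c(/C=C/S(=O)(=O)Cc2ccc(Br)c(N)c2)c(OC)c1`: 750 nM
- compound 3, `COc1cc(OC)c(/C=C/S(=O)(=O)Cc2ccc(Cl)cc2N)c(OC)c1`: 2500 nM

These three compounds were tested in a functional assay on K562 cells (Homo sapiens) for cytotoxicity, read by trypan blue exclusion, with a stated time of 96 h; on this read-out higher numbers stand for weaker inhibition and lower numbers for stronger inhibition. Compound 1 gives the lowest number of the three, so it is the strongest inhibitor here; the nearest of the others is compound 2, and the step of a 300-fold higher number from compound 1 to compound 2 (2.48 log units; beyond the scatter), while the step of a 1000-fold higher number from compound 1 to compound 3 (3.00 log units; beyond the scatter) is larger still. Between the two weaker compounds the step of a 3.3-fold higher number from compound 2 to compound 3 (0.52 log units; beyond the scatter) is modest.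

Compound 4, `COc1cc(OC)c(/C=C/S(=O)(=O)Cc2ccc(OC)c(NC(C(=O)O)c3ccc(F)cc3)c2)c(OC)c1`, has not been measured. It differs from compound 1 in one place: carboxy(4-fluorophenyl)methyl in place of hydrogen on a nitrogen on an aromatic ring. In other words, the amino group becomes a (carboxy(4-fluorophenyl)methyl)amino group.

Among the measured compounds shown here, none of the measured steps touches the nitrogen itself; they all alter groups on the ring carbons, and each of them raises the number sharply. They show that compound 1 tolerates little change around that ring, but they give no direct guide for adding a large group on the nitrogen. An increase in the number is therefore expected, of uncertain size, with the step of a 12-fold higher number from compound 1 to compound 4 (1.08 log units; beyond the scatter). Compound 4 is estimated at 30 nM, within a range from 3 nM to 300 nM.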

Compound 4, half-maximal inhibitory concentration: 80 nM
Estimate against measurement, compound 4: 2.7-fold (0.43 log units) below, within the range that was stated.
By their numbers in this assay, from the lowest: compound 1; then compound 4; then compound 2; then compound 3.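

In this assay, among the compounds shown here, compound 4 is the only compound here changed on the nitrogen itself, and placing a carboxy(4-fluorophenyl)methyl group there gives a 32-fold higher number from compound 1 to compound 4 (1.51 log units; beyond the scatter). The hydrogen on this nitrogen therefore cannot be replaced without a clear loss of activity, at least with this group, yet it does not have to remain for activity to be measured: compound 4, carrying this added side chain, still gives 80 nM in this cell test. Nothing measured here explains the loss, and no supporting data bear on the cause of this step.

This single change adds a new aromatic ring and a carboxylic acid together, so the compounds shown cannot separate what each part contributes to the step. A methyl ester in place of the carboxylic acid, a plain phenyl in place of the 4-fluorophenyl, or a small methyl group alone on the nitrogen would each alter one part of that side chain and show which part matters most.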